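A bromo to methoxy swap at the assay limit

This account rests on a few compounds, and the source may have more. Where it says the series, first, only, none or still open, it means among the compounds named here.

Measured in a functional assay on MCF7 cells (Homo sapiens) for cytotoxicity, read by MTT assay, with a stated time of 72 h; a lower number here means a stronger inhibitor, a higher number a weaker inhibitor (all three values are limits):
compound 1 `CCOC(=O)c1c(C)oc2ncnc(Nc3cccc(C)c3)c12` gives > 1000000 nM
compound 2 `C#Cc1cccc(Nc2ncnc3oc(C)c(C(=O)OCC)c23)c1` gives > 1000000 nM
compound 3 `CCOC(=O)c1c(C)oc2ncnc(Nc3cccc(Br)c3)c12` gives > 1000000 nM

Compound 3 has only the limit > 1000000 nM and no actual number. The two other measured compounds sit at the same place (the limit of > 1000000 nM in this assay, at which 3 of the 3 values shown sit).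

The change to compound 4 `CCOC(=O)c1c(C)oc2ncnc(Nc3cccc(OC)c3)c12` is methoxy in place of bromo on an aromatic carbon. The nearest evidence is three other swaps on an aromatic carbon: one is a step that the two limits leave unreadable from compound 1 to compound 2 and another is a step that the two limits leave unreadable from compound 1 to compound 3 and the third is a step that the two limits leave unreadable from compound 2 to compound 3 and none has a size that can be read. So this assay offers no measured size and no direction, and no step beyond the scatter is expected. With compound 3 at the limit > 1000000 nM the most likely result for compound 4 is another limit.

The estimated change is a number no higher from compound 3 to compound 4 (the limit leaves the size open) and it carries no expected direction. Compound 4 is estimated at 1000000 nM with an expected range from 300000 nM to 3000000 nM in this assay for now.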

Compound 4, half-maximal inhibitory concentration: > 1000000 nM
Compound 4 gave a limit, no number; the forecaster's own chance of this, stated with the estimate: 85%; the middle value lies on the limit itself.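

No step can be read between compound 1, compound 2, compound 3 and compound 4 in this assay, since each step joins two limits: the limit of > 1000000 nM in this assay, at which 4 of the 4 values shown sit.

The compounds shown leave open whether methyl, ethynyl, bromo and methoxy differ in strength at all, and how they would rank.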